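Substitution on the ring amine nitrogen of compound 2

The source may report more compounds than this note shows. Statements on the series, on what has been measured and on what is new or still open speak of the compounds shown alone.

In a functional assay on PC-3 cells (Homo sapiens) for cytotoxicity, read by MTT assay, with a stated time of 72 h (a higher number here means a weaker inhibitor, a lower number a stronger inhibitor), compound 1 `CNC(=O)c1cc(Oc2ccc(C3=NNC(c4cccc(Br)c4)C3)cc2)ccn1` gives 3540 nM. Compound 2 `CNC(=O)c1cc(Oc2ccc(C3=NNC(c4cccc(Cl)c4Cl)C3)cc2)ccn1` has no single number to stand on, its entry reading "not determined" (no result reported). Going by these compounds, its place therefore stays open, and no comparison with compound 1 can be drawn. Compound 3 `CNC(=O)c1cc(Oc2ccc(C3=NN(C(N)=S)C(c4cccc(Cl)c4Cl)C3)cc2)ccn1` is the structure to be tested next. The structural change is a group of 3 heavy atoms (1 carbon, 1 nitrogen, 1 sulfur; no ring) in place of a hydrogen atom, on an amine nitrogen in a ring: a group of 3 heavy atoms in place of a hydrogen atom, on an amine nitrogen in a ring, next to the ring atom that bears a 2,3-dichlorophenyl group. Among the measured compounds shown here, no measured step shows what such a change does. In this assay, a small step towards a lower number is expected, possibly none beyond the scatter, with compound 1 at 3540 nM as the only anchor. Compound 3 is estimated at 2500 nM, with an expected range of 600 nM to 10000 nM.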

Compound 3, half-maximal inhibitory concentration: 15900 nM
Compound 3: the middle estimate sits 6.4-fold (0.80 log units) below what was measured, outside the stated range (above it).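

No step can be read from compound 2 to compound 3: in this assay compound 2 has no single number, leaving compound 3 at 15900 nM without a partner that differs in one place. Going by these compounds, what the group entering on the ring amine nitrogen does to the value stays open, and no available evidence bears on this result.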